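Fluoro to methoxymethyl on the outer aryl ring

The compounds below may be only part of what the source reports. "The series", "measured", "known", "first", "only" and "open" are said of these compounds alone.

Measured so far:
compound 1 `CC[C@@H](Nc1c(C#N)c(-c2ccc(-c3ccccc3F)cc2)nc2cnccc12)C(N)=O` — 2.7
compound 2 `CCOc1ccccc1-c1ccc(-c2nc3cnccc3c(C[C@H](C)C(=O)O)c2C#N)cc1` — 2.2
compound 3 `CCOc1ccccc1-c1ccc(-c2nc(NC(C)C(=O)O)c3ccncc3n2)cc1` — 2.1

In a physicochemical assay for lipophilicity, read by HPLC, at pH 7.5 (a lower number here means a more polar compound, a higher number a more lipophilic compound), compound 1 gives 2.7, the highest of the three values. Compound 2 sits lower by a margin beyond the scatter, and compound 3 lower still, also beyond the scatter. No two of these three compounds differ in a single place, so no single-change step can be read from the measurements.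

The unmeasured compound 4 `CC[C@@H](Nc1c(C#N)c(-c2ccc(-c3ccccc3COC)cc2)nc2cnccc12)C(N)=O` is reached from compound 1 by one change: methoxymethyl in place of fluoro on an aromatic carbon The change sits on an aromatic carbon of a six-membered aromatic ring of carbon only. For compound 4 a downward step beyond the scatter is expected, a number 0.50 log units lower from compound 1 to compound 4 (beyond the scatter). In this assay compound 4 is estimated at 2.2, with a range from 1.7 to 2.7.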

Compound 4, distribution coefficient: 2.6
Compound 4: middle estimate off by 0.40 log units, on the low side, and the stated range covers the measured number.
By their numbers in this assay, from the lowest: compounds 3 and 2 (each within the scatter of the next); then compounds 4 and 1 (each within the scatter of the next).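

In this assay, among these compounds, the first single-change step (a number 0.10 log units lower from compound 1 to compound 4 (within the scatter)) shows that, at this place on an aromatic carbon ortho to a large group, methoxymethyl and fluoro give values within the scatter of each other. This holds even though the entering group adds heavy atoms and a hydrogen-bond acceptor. Nothing available explains this result.

Still open, on these data alone, is whether an amine, a carboxylic acid or a longer ether chain at this place would also stay within the scatter of compound 1 in this assay.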